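Methoxy on the aryl ring: a repeated change on two cores

The source may report more compounds than this note shows. Statements on the series, on what has been measured and on what is new or still open speak of the compounds shown alone.

Compound 1 `Cn1c(=O)[nH]c2nc(SCC(=O)c3ccccc3)[nH]c2c1=O` carries a phenyl ring on a ketone-linked side chain attached to its core. In a functional assay on MCF7 cells (Homo sapiens) for inhibition, read by MTT assay, with a stated time of 48 h (a higher number here means a weaker inhibitor, a lower number a stronger inhibitor), compound 1 gives 11600 nM. Compound 2 `COc1ccc(C(=O)CSc2nc3[nH]c(=O)n(C)c(=O)c3[nH]2)cc1` differs from compound 1 in one place, (methoxy in place of hydrogen on an aromatic carbon), and in this assay compound 2 gives 5900 nM. Within the data shown here, the step of a 2.0-fold lower number from compound 1 to compound 2 (0.29 log units; within the scatter) is the only measured instance of this change.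

Compound 3 `Cn1c(=O)c2[nH]c(SC/C(=N/O)c3ccccc3)nc2n(C)c1=O` has a different core and an oxime in place of the ketone; the difference between the two cores is not broken down here. In this assay compound 3 gives 5900 nM, which is level with compound 2 at the digits shown and within the scatter of compound 1.

Compound 4 `COc1ccc(/C(CSc2nc3c([nH]2)c(=O)n(C)c(=O)n3C)=N\O)cc1` is not yet measured. It differs from compound 3 by methoxy in place of hydrogen on an aromatic carbon, the same change that leads from compound 1 to compound 2, made on the other core. Among the measured compounds shown here, on the evidence of the single measured step, which was within the scatter, a step of about the same size is expected from compound 3 to compound 4, a 1.5-fold lower number from compound 3 to compound 4 (0.17 log units; within the scatter), because the step of a 2.0-fold lower number from compound 1 to compound 2 (0.29 log units; within the scatter) was itself small. Compound 4 is therefore expected to give about 4000 nM in this assay, with a plausible range from 1500 nM to 12000 nM.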

Compound 4, half-maximal inhibitory concentration: 800 nM
The estimate for compound 4 lay 5.0-fold (0.70 log units) above the measured number; the whole stated range lies above it.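

In this assay, the change from phenyl to 4-methoxyphenyl gives a 7.4-fold lower number from compound 3 to compound 4 (0.87 log units; beyond the scatter), a step beyond the scatter, and it does not match the step made by the same change on the other core: the same change on two cores in this assay, a 2.0-fold lower number (0.29 log units; within the scatter) from compound 1 to compound 2 and a 7.4-fold lower number (0.87 log units; beyond the scatter) from compound 3 to compound 4, 3.8-fold (0.57 log units) apart, beyond the scatter of two such steps

Among these compounds, the change therefore did not carry over with a fixed size, although the number fell in both pairs, and only the pair of compound 3 and compound 4 shows a step that stands clear of the scatter. What this does not show is which feature goes with the larger step, as the two pairs differ both in their core and in having a ketone or an oxime in the side chain, and two pairs are too few to establish any general rule for moving this change between cores.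

The compounds shown leave open how the methoxy change would behave with an oxime on the core of compound 1 or with a ketone on the core of compound 3, which is the comparison that would separate those two differences. They also leave open whether an ethoxy group, an amine or a carboxylic acid in the same place on the ring would follow the methoxy group.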